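Benzylthio variation on the shared core: compound 4

The source may report more compounds than this note shows. Statements on the series, on what has been measured and on what is new or still open speak of the compounds shown alone.

Measured so far:
- compound 1 `Cc1cc(S(=O)(=O)/N=C(\N)N/N=C/C#Cc2ccccc2)c(SCc2ccccc2C(F)(F)F)cc1Cl`: 14000 nM
- compound 2 `Cc1cc(S(=O)(=O)/N=C(\N)N/N=C/C#Cc2ccccc2)c(SCc2ccc(C(F)(F)F)cc2)cc1Cl`: 105000 nM
- compound 3 `Cc1cc(S(=O)(=O)/N=C(\N)N/N=C/C#Cc2ccccc2)c(SCc2ccc(Cl)cc2)cc1Cl`: 18000 nM

All three share one core and differ only in the group on the saturated chain carbon bound to a sulfur. In a functional assay on MCF7 cells (Homo sapiens) for antiproliferative activity, read by MTT assay, with a stated time of 72 h (a lower number here means a stronger inhibitor, a higher number a weaker inhibitor), compound 3 stands second highest of the three numbers; its nearest neighbour is compound 1, the step of a 1.3-fold higher number from compound 1 to compound 3 (0.11 log units; within the scatter) being within the scatter, while the step of a 5.8-fold lower number from compound 2 to compound 3 (0.77 log units; beyond the scatter) is beyond it. The remaining step, a 7.5-fold higher number from compound 1 to compound 2 (0.88 log units; beyond the scatter), is of similar size in the other direction.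

Compound 4 `Cc1cc(S(=O)(=O)/N=C(\N)N/N=C/C#Cc2ccccc2)c(SCc2cccc3ccccc23)cc1Cl` is not yet measured. Its difference from compound 3 is naphthalen-1-yl in place of 4-chlorophenyl on a saturated chain carbon bound to a sulfur. For the measured compounds named here, none of the measured steps exchanges the aromatic ring itself; they exchange substituents on a phenyl ring, and only one of them, a 5.8-fold lower number from compound 2 to compound 3 (0.77 log units; beyond the scatter), moves the number beyond the scatter. Going by the values given here, no step therefore bears directly on a fused second ring, and the change is treated as comparable to the substituent swaps seen, with wide uncertainty.

For compound 4 in this assay the expected value is 15000 nM (range 4000 nM to 60000 nM), an estimated step of a 1.2-fold lower number from compound 3 to compound 4 (0.08 log units; within the scatter) expected to lie within the scatter.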

Compound 4, half-maximal inhibitory concentration: 22000 nM
For compound 4 the middle estimate is 1.5-fold (0.17 log units) below the measured one; the measured number falls inside the stated range.
By their numbers in this assay, from the lowest: compounds 1, 3 and 4 (each within the scatter of the next); then compound 2.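

In this assay a second fused ring on the saturated chain carbon bound to a sulfur gives a number that cannot be told apart from those of the single-ring groups: a 1.2-fold higher number from compound 3 to compound 4 (0.09 log units; within the scatter) and a 1.6-fold higher number from compound 1 to compound 4 (0.20 log units; within the scatter) both sit within the scatter, even though naphthalen-1-yl has 10 heavy atoms against 7 for 4-chlorophenyl. Compound 2 now stands apart from all three others, with a 4.8-fold lower number from compound 2 to compound 4 (0.68 log units; beyond the scatter) beyond the scatter, so that in this set of four groups only 4-(trifluoromethyl)phenyl separates from the rest, and exchanging the aromatic ring itself does not. Nothing on hand accounts for either the flat result or the separate place of compound 2.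

Still open is whether any group at this position can bring the number clearly below the shared level of compound 1, compound 3 and compound 4, since every group shown is an aromatic ring of carbon only with no hydrogen-bond donors or acceptors. An amine or a carboxylic acid on that ring, or a longer chain in place of the saturated chain carbon bound to a sulfur, would test this.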